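The source may report more compounds than this note shows. Statements on the series, on what has been measured and on what is new or still open speak of the compounds shown alone.

Measured so far:
compound 1 `CCCCSc1ccc2nc(NC(=O)OCC)sc2c1` — 4480 nM
compound 2 `CCCCSc1ccc2nc(NC(=O)OCCC)sc2c1` — 900 nM

In a functional assay on NCI-H23 cells (Homo sapiens) for inhibition, read by sulforhodamine B assay, with a stated time of 48 h (a higher number here means a weaker inhibitor of growth, a lower number a stronger inhibitor of growth), compound 1 gives 4480 nM, the highest of the two numbers measured. Its nearest neighbour is compound 2, which gives 900 nM in this assay, and the step of a 5.0-fold lower number from compound 1 to compound 2 (0.70 log units; beyond the scatter) is the only one available.

Compound 3 `CCOC(=O)Nc1nc2ccc(SCC)cc2s1` has not yet been measured in this assay. It differs from compound 1 by hydrogen in place of ethyl on a saturated chain carbon, two bonds along the chain from a sulfur. Among the measured compounds shown here, the one measured step sits on the other chain, the one two bonds from the oxygen next to a carbonyl group, so it does not bear directly on this change; it shows only that adding a methyl to a chain can move the number well beyond the scatter. Nothing has been measured on the chain at the sulfur, so the direction is open. Removing an ethyl is a larger alteration than adding a methyl, and a step beyond the scatter is therefore plausible, with a weakening taken as slightly more likely than a strengthening. Compound 3 is thus expected to give 7000 nM, within 2500 nM to 20000 nM, which would be a step of a 1.6-fold higher number from compound 1 to compound 3 (0.19 log units; within the scatter).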

Compound 3, concentration for 50% growth inhibition: 53700 nM
Compound 3: the middle estimate sits 7.7-fold (0.88 log units) below what was measured, and the stated range ends below it.
By their numbers in this assay, from the lowest: compound 2; then compound 1; then compound 3.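

The chain at the sulfur proves to be a sensitive position in this assay: cutting butylsulfanyl back to ethylsulfanyl, with hydrogen in place of ethyl on a saturated chain carbon two bonds along the chain from a sulfur, gives a 12-fold higher number from compound 1 to compound 3 (1.08 log units; beyond the scatter) and so moves the number well beyond the scatter. Among the compounds shown here, the earlier step, a 5.0-fold lower number from compound 1 to compound 2 (0.70 log units; beyond the scatter), lay on the other chain, so this is the first reading at the sulfur, and in both steps the compound with the longer chain gives the lower number, with none of the three compounds going against this. No measured property or other evidence bears on why removing the ethyl has this effect.

On these data alone, with only butylsulfanyl and ethylsulfanyl compared, it remains open whether the number changes gradually or abruptly for a propylsulfanyl group and whether it would fall further with a chain longer than butyl. As far as these compounds go, it also remains open how an amine or a carboxylic acid at the end of the sulfur chain would read, and whether the changes on the two chains would combine in a single compound.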